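The compounds below may be only part of what the source reports. "The series", "measured", "known", "first", "only" and "open" are said of these compounds alone.

Measured so far:
compound 1 `Brc1cn2ccnc2c(-c2ccc3ncn(C4CCCCC4)c3c2)n1`: 6.47%
compound 2 `Fc1ccc(-c2cn3ccnc3c(-c3ccc4ncn(C5CCCCC5)c4c3)n2)cc1`: 3.97%
compound 3 `Clc1ccc(-c2cn3ccnc3c(-c3ccc4ncn(C5CCCCC5)c4c3)n2)cc1`: 13.5%

In a functional assay on SN12C cells (Homo sapiens) for inhibition, read by sulforhodamine B assay, with a stated time of 48 h, tested at 10 uM (on this read-out higher numbers stand for more inhibition at the one concentration tested (going by the name of the read-out) and lower numbers for less inhibition), compound 3 shows the largest of the three numbers, yet neither gap to the others reaches beyond the scatter: a number 7 percentage points higher from compound 1 to compound 3 (within the scatter) and a number 9.5 percentage points higher from compound 2 to compound 3 (within the scatter). Compound 4 `Brc1ccc(-c2cn3ccnc3c(-c3ccc4ncn(C5CCCCC5)c4c3)n2)cc1` differs from compound 3 by bromo in place of chloro on an aromatic carbon. Within the data shown here, the one measured step that bears on this is the earlier halogen exchange at the same carbon, a number 9.5 percentage points higher from compound 2 to compound 3 (within the scatter), which stayed within the scatter; the step of a number 2.5 percentage points lower from compound 1 to compound 2 (within the scatter) likewise changed little. Nothing among the three compounds points to a shift beyond the scatter for compound 4. For compound 4 in this assay the expected value is therefore 14%, within 4% to 24%, an estimated step of a number 0.5 percentage points higher from compound 3 to compound 4 (within the scatter).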

Compound 4, a percentage reported as inhibition, at one concentration (the size of the read-out at that concentration, not a potency): 18.4%
The estimate for compound 4 lay 4.4 percentage points below the measured number, within the range that was stated.
By their numbers in this assay, from the lowest: compounds 2, 1, 3 and 4 (each within the scatter of the next, the first and the last beyond it).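

In this assay, among these compounds, bromo in place of chloro on this aromatic carbon gives a number 4.9 percentage points higher from compound 3 to compound 4 (within the scatter), but bromo in place of fluoro gives a number 14.4 percentage points higher from compound 2 to compound 4 (beyond the scatter), the first exchange of one halogen for another at this carbon to pass the scatter, if only modestly. The change from bromo on the core to 4-bromophenyl gives a number 11.9 percentage points higher from compound 1 to compound 4 (beyond the scatter), whereas the 4-fluorophenyl and 4-chlorophenyl changes stayed within the scatter. No measurement at hand accounts for these steps. As far as these compounds go, whether an amine or a carboxylic acid in place of the bromo on this six-membered ring would shift the number further remains open.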